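The source may hold more compounds than are shown below. What is called first, only, known or untested is meant among the compounds shown, and "the series" means these compounds.

Working notes on the series. Compound 1 `O/N=C(/Nc1ccccc1)c1ccc2occc2c1` is the parent; in an assay on tissue (HeLa cells) for inhibition of Indoleamine 2,3-dioxygenase 1 (Homo sapiens), read by spectrophotometry (a lower number here means a stronger inhibitor, a higher number a weaker inhibitor), compound 1 gives 19000 nM. Compound 2 `O/N=C(/Nc1cccc(F)c1)c1ccc2occc2c1` carries fluoro in place of hydrogen on an aromatic carbon, and in this assay compound 2 gives 20000 nM; the step is a 1.1-fold higher number from compound 1 to compound 2 (0.02 log units; within the scatter). Compound 3 `CC(=O)c1cccc(N/C(=N/O)c2ccc3occc3c2)c1` carries acetyl on an aromatic carbon. For compound 3 this assay records only a limit, > 30000 nM. The steps of an at least 1.5-fold higher number from compound 1 to compound 3 (0.19 log units; that floor lies within the scatter) and an at least 1.5-fold higher number from compound 2 to compound 3 (0.17 log units; that floor lies within the scatter) are therefore floors only, set by the limit of > 30000 nM in this assay, at which 1 of the 3 values shown sits.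

Compound 4 `O=C(NCC1CCCCC1)c1cccc(N/C(=N/O)c2ccc3occc3c2)c1` is the next move from compound 3: (cyclohexylmethyl)amino in place of methyl on a carbonyl carbon. No measured step touches the carbonyl carbon, so nothing shown gives the size or direction of this change. Within the data shown here, the only anchor is where compound 3 stands, at the floor of the assay. The expected step is a number no higher from compound 3 to compound 4 (the limit leaves the size open), meaning no move that the data would resolve. Compound 4 is estimated at 30000 nM, within a range from 6000 nM to 150000 nM, with a real chance that this assay again returns only a limit.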

Compound 4, half-maximal inhibitory concentration: > 30000 nM
Compound 4: no number, only a limit; the forecaster's own chance of this, stated with the estimate: 50%; the middle value sits exactly at the limit.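

In this assay compound 4 returns only a limit, > 30000 nM. Compound 3 also stands at a limit, so no step between compound 3 and compound 4 can be read: the limit of > 30000 nM in this assay, at which 2 of the 4 values shown sit.

The compounds shown leave open whether (cyclohexylmethyl)amino in place of methyl on a carbonyl carbon changes the number at all, and in which direction.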